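Cytotoxicity notes: swapping the amine on the carbonyl carbon

A few compounds are considered here, and "the series" means these few. Any claim that something is new, unique, unknown or untested is made for them only; others in the source may bear on it.

In an ADME assay on BE(2)-C cells (Homo sapiens) for cytotoxicity, read by MTT assay, with a stated time of 20 h (a lower number here means that less compound is tolerated, a higher number that more compound is tolerated), compound 1 (`O=C(NCC1COc2cnccc21)C1CCN(C(=O)c2cc3ccccc3n2Cc2ccc(Cl)cc2)CC1`) gives 75800 nM. Compound 2 (`O=C(c1cc2ccccc2n1Cc1ccc(Cl)cc1)N1CCC(C(=O)N2CCC[C@H]2CO)CC1`) gives 98900 nM, which lies within the scatter of the other value, so the two cannot be separated on these numbers.

The next structure is compound 3 (`CN(Cc1ccccc1)C(=O)C1CCN(C(=O)c2cc3ccccc3n2Cc2ccc(Cl)cc2)CC1`), which carries benzyl(methyl)amino in place of 2-(hydroxymethyl)pyrrolidin-1-yl on a carbonyl carbon. Among the measured compounds shown here, only one measured step bears on this change. That step, a 1.3-fold higher number from compound 1 to compound 2 (0.12 log units; within the scatter), also exchanges the group on a carbonyl carbon and stays within the scatter. For the measured compounds named here, it is thin evidence, since no measured compound carries benzyl(methyl)amino. No step beyond the scatter is therefore expected in this assay.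

The expected step is a 1.3-fold lower number from compound 2 to compound 3 (0.12 log units; within the scatter). The estimate for compound 3 is 75000 nM, with an expected range of 35000 nM to 130000 nM.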

Compound 3, half-maximal cytotoxic concentration: 87000 nM
Estimate against measurement, compound 3: 1.2-fold (0.06 log units) below; the measured number falls inside the stated range.
By their numbers in this assay, from the lowest: compounds 1, 3 and 2 (each within the scatter of the next).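

In this assay the exchange on the carbonyl carbon gives a 1.1-fold lower number from compound 2 to compound 3 (0.06 log units; within the scatter) and the comparison with the remaining amide gives a 1.1-fold higher number from compound 1 to compound 3 (0.06 log units; within the scatter) as well. Benzyl(methyl)amino, with its six-membered aromatic ring of carbon only and no hydroxymethyl, therefore joins the two earlier groups, and the three amines on this carbonyl carbon cannot be separated on these numbers. Nothing measured here accounts for this flat reading.

The compounds shown leave open whether a carboxylic acid, or a longer chain such as phenethyl(methyl)amino, on this carbonyl carbon would give a step beyond the scatter. They also leave open whether a change elsewhere on the shared core, such as replacing the chlorine on the benzyl group with a methoxy group, would do so.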